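A Larger Aromatic Group on the Amine Nitrogen

The source may report more compounds than this note shows. Statements on the series, on what has been measured and on what is new or still open speak of the compounds shown alone.

In a functional assay on HeLa cells (Homo sapiens) for inhibition, read by MTT assay, with a stated time of 48 h (a lower number here means a stronger inhibitor, a higher number a weaker inhibitor), compound 3 (`CCOC(=O)C1=C(N/N=C(/Cl)C#N)Nc2[nH]nc(C)c2C1c1ccc(N(C)C)cc1`) gives 26200 nM and so stands within the scatter of compound 1 (`CCOC(=O)C1=C(NN=C(C#N)C#N)Nc2[nH]nc(C)c2C1c1ccc(N(C)C)cc1`) at 15200 nM and of compound 2 (`CCOC(=O)C1=C(N/N=C(/Cl)c2ccc([N+](=O)[O-])cc2)Nc2[nH]nc(C)c2C1c1ccc(N(C)C)cc1`) at 46200 nM alike. The change to compound 4 (`CCOC(=O)C1=C(N/N=C(/C(=O)Br)c2ccc(Cl)cc2)Nc2[nH]nc(C)c2C1c1ccc(N(C)C)cc1`) is a group of 12 heavy atoms (8 carbon, 1 nitrogen, 1 oxygen, 1 chlorine, 1 bromine; one six-membered aromatic ring of carbon only) in place of a group of 5 heavy atoms (2 carbon, 2 nitrogen, 1 chlorine; no ring), on an amine nitrogen and the rest of the structure stays the same. Among the measured compounds shown here, the closest precedent is a 3.0-fold higher number from compound 1 to compound 2 (0.48 log units; beyond the scatter) on taking up a ring-bearing group of similar size, a modest step. Against it stands a 1.8-fold lower number from compound 2 to compound 3 (0.25 log units; within the scatter) for cyano in place of 4-nitrophenyl, which remains within the scatter. A small step toward a higher number in this assay is therefore expected, with a 1.5-fold higher number from compound 3 to compound 4 (0.16 log units; within the scatter) as the estimate. For compound 4 the expected value is 38000 nM with an estimated range from 16000 nM to 85000 nM in this measurement.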

Compound 4, half-maximal inhibitory concentration: 49300 nM
Beside the measured number, compound 4's estimate is 1.3-fold (0.11 log units) below it; the range from low to high includes it.
By their numbers in this assay, from the lowest: compounds 1, 3, 2 and 4 (each within the scatter of the next, the first and the last beyond it).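

Compound 2 and compound 4, whose groups on the amine nitrogen each carry one six-membered aromatic ring of carbon only, stand level (a 1.1-fold higher number from compound 2 to compound 4 (0.03 log units; within the scatter)). Both now lie beyond the scatter of compound 1, compound 4 by a modest step (a 3.2-fold higher number from compound 1 to compound 4 (0.51 log units; beyond the scatter)), yet compound 3, whose group has no ring, cannot be told apart from compound 4 (a 1.9-fold higher number from compound 3 to compound 4 (0.27 log units; within the scatter)). No evidence on the cause of these numbers is at hand. On these data alone, it stays open what a carboxylic acid or an amine in place of the bromine-bearing carbonyl of compound 4 would give in this assay.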